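The source may report more compounds than this note shows. Statements on the series, on what has been measured and on what is new or still open speak of the compounds shown alone.

Compound 1 `CN1CCN(CCCOc2cccc3nc(Nc4ccc(Cl)c(C(F)(F)F)c4)ccc23)CC1`: 3170 nM
Compound 2 `CN1CCN(CCCOc2cccc3nc(Nc4cc(Cl)cc(Cl)c4)ccc23)CC1`: 3190 nM
Compound 3 `CN1CCN(CCCOc2cccc3nc(Nc4cccc(Cl)c4)ccc23)CC1`: not yet measured

In a functional assay on cells (Panel colon (Carcinoma cell lines), Homo sapiens) for inhibition, read by sulforhodamine B assay, with a stated time of 48 h (on this read-out lower numbers stand for stronger inhibition of growth and higher numbers for weaker inhibition of growth), compound 1 gives 3170 nM. For the measured compounds named here, only one other measured compound is available for comparison, and the step is a 1.0-fold higher number from compound 1 to compound 2 (0.00 log units; within the scatter), so the two cannot be ranked.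

The change under consideration is 3-chlorophenyl in place of 4-chloro-3-(trifluoromethyl)phenyl on a nitrogen on an aromatic ring. In words, this puts 3-chlorophenyl in place of 4-chloro-3-(trifluoromethyl)phenyl on a nitrogen on an aromatic ring, while the shared core and the rest of the molecule stay the same.

Going by the values given here, one measured step bears on this change: the same group at the same place gives way to 3,5-dichlorophenyl in compound 2. Among the compounds with values here, with a 1.0-fold higher number from compound 1 to compound 2 (0.00 log units; within the scatter) as the only guide, no step beyond the scatter is expected in this assay. Within the data shown here, a single step is thin evidence, and no measured compound carries 3-chlorophenyl, so the range is kept wide.

The estimate means an expected 1.1-fold higher number from compound 1 to compound 3 (0.03 log units; within the scatter). Compound 3 is expected at 3400 nM, with an estimated range of 1800 nM to 6500 nM.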

Compound 3, concentration for total growth inhibition: 3100 nM
The estimate for compound 3 lay 1.1-fold (0.04 log units) above the measured number, within the range that was stated.
By their numbers in this assay, from the lowest: compounds 3, 1 and 2 (each within the scatter of the next).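

In this assay, 3-chlorophenyl in place of 4-chloro-3-(trifluoromethyl)phenyl on the nitrogen leaves the read-out within the scatter (with a 1.0-fold lower number from compound 1 to compound 3 (0.01 log units; within the scatter)), even though the group drops from 11 heavy atoms to 7. Hydrogen in place of chloro on an aromatic carbon also gives no readable difference (with a 1.0-fold lower number from compound 2 to compound 3 (0.01 log units; within the scatter)). For the compounds shown here, the earlier pair showed only that two larger substituted rings could not be separated, whereas these steps extend that result to a smaller ring carrying a single chloro, so the three groups at this position cannot be ranked.

No measurement at hand accounts for this flat result.

The compounds shown leave open whether any group on this ring is needed at all, since a plain phenyl would test the series without its chloro. From the compounds shown here alone, it also remains open whether a more different group in the place of the chloro, such as an amine, a carboxylic acid or a nitrile, would produce a step beyond the scatter.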